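Swapping a hydroxyethyl tail for an ethynyl group

A few compounds are considered here, and "the series" means these few. Any claim that something is new, unique, unknown or untested is made for them only; others in the source may bear on it.

Of the compounds shown here, two with a shared core have been measured in an assay on isolated protein for inhibition of retinal dehydrogenase 2 (Homo sapiens); on this read-out lower numbers stand for stronger inhibition and higher numbers for weaker inhibition. Compound 1 `CC(Sc1nc2c(cnn2C)c(=O)n1-c1ccc(CCO)cc1)c1ccccc1` carries a phenyl ring bearing a 2-hydroxyethyl group; in this assay compound 1 gives 216 nM. Compound 2 `CC(Sc1nc2c(cnn2C)c(=O)n1-c1ccccc1)c1ccccn1` has a plain phenyl ring and a pyridyl group in place of the second phenyl; in this assay compound 2 gives 63 nM. Of the two numbers, compound 1 stands at the higher one, and the gap to compound 2 lies beyond the usual scatter, but since the two structures differ in two places at once, no single change can be read from that pair.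

Compound 3 `C#Cc1ccc(-n2c(SC(C)c3ccccc3)nc3c(cnn3C)c2=O)cc1` is not yet measured. It differs from compound 1 in one place: ethynyl in place of 2-hydroxyethyl on an aromatic carbon. Going by the values given here, there is no measured pair showing this particular change, so any expectation rests on compound 1 alone. With nothing pointing one way or the other, the step from a 1.2-fold lower number from compound 1 to compound 3 (0.08 log units; within the scatter) is expected to stay within the scatter. Compound 3 is therefore estimated at 180 nM, with a plausible range from 60 nM to 540 nM.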

Compound 3, half-maximal inhibitory concentration: 800 nM
Estimate against measurement, compound 3: 4.4-fold (0.65 log units) below; the whole stated range lies below it.
By their numbers in this assay, from the lowest: compound 2; then compound 1; then compound 3.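

In this assay, the group on the aromatic carbon para to a large group clearly affects the read-out: ethynyl in place of 2-hydroxyethyl gives a 3.7-fold higher number from compound 1 to compound 3 (0.57 log units; beyond the scatter). Going by these compounds alone, this is the first single-place comparison, since compound 1 and compound 2 differ in two places at once, so it is the first step that can be tied to one position and one change. The swap alters several things together, as the departing 2-hydroxyethyl has 3 heavy atoms, a hydrogen-bond donor and a hydrogen-bond acceptor, while the incoming ethynyl has 2 heavy atoms, a triple bond and neither donor nor acceptor, and no measurement here explains the loss of inhibition.

Still open, as far as these compounds go, is which of these differences matters, and an ethyl group, a 2-methoxyethyl group or a longer 3-hydroxypropyl chain at the same place would help to separate them. Compound 2 has a plain phenyl ring but also carries a pyridyl group, so the compounds shown do not reveal how the core of compound 1 behaves with no group at this position.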